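Replacing 3,4-Dimethoxyphenyl with 3-(Diethylamino)propyl on an Amide Nitrogen

The compounds below may be only part of what the source reports. "The series", "measured", "known", "first", "only" and "open" are said of these compounds alone.

Of the compounds shown here, three sharing one core have been measured in an ADME assay on HUVEC cells (Homo sapiens) for cytotoxicity, read by MTT assay, with a stated time of 72 h; a lower number here means a stronger inhibitor, a higher number a weaker inhibitor. Compound 1 `O=C(O)CCC(=O)OCCCCCCSc1ccc([N+](=O)[O-])c2nonc12`, with a hydroxy on a carbonyl carbon, gives 740 nM. Compound 2 `O=C(CCC(=O)OCCCCCCSc1ccc([N+](=O)[O-])c2nonc12)Nc1cccc(Cl)c1`, which carries (3-chlorophenyl)amino there, gives 1090 nM. Compound 3 `COc1ccc(NC(=O)CCC(=O)OCCCCCCSc2ccc([N+](=O)[O-])c3nonc23)cc1OC`, which carries (3,4-dimethoxyphenyl)amino, gives 870 nM, within the scatter of both others, so the three cannot be ranked.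

Compound 4 `CCN(CC)CCCNC(=O)CCC(=O)OCCCCCCSc1ccc([N+](=O)[O-])c2nonc12` changes this same place: 3-(diethylamino)propyl in place of 3,4-dimethoxyphenyl on an amide-type nitrogen. In short, 3-(diethylamino)propyl stands in place of 3,4-dimethoxyphenyl on an amide-type nitrogen.

Two measured steps changed the group on that carbonyl carbon: a 1.5-fold higher number from compound 1 to compound 2 (0.17 log units; within the scatter) and a 1.2-fold higher number from compound 1 to compound 3 (0.07 log units; within the scatter). Closest to the new change is a 1.3-fold lower number from compound 2 to compound 3 (0.10 log units; within the scatter), a swap on the amide-type nitrogen itself. All three stay within the scatter, but none brought in a chain like this one, so they are only a loose guide. From these steps, the expected move is a 1.1-fold lower number from compound 3 to compound 4 (0.04 log units; within the scatter), with no real change foreseen. For compound 4 the estimated value is 800 nM, with an expected range from 380 nM to 1700 nM.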

Compound 4, half-maximal inhibitory concentration: 2950 nM
The estimate for compound 4 lay 3.7-fold (0.57 log units) below the measured number; measured number above the stated range.
By their numbers in this assay, from the lowest: compounds 1, 3 and 2 (each within the scatter of the next); then compound 4.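

In this assay the group on the amide-type nitrogen does matter: the 3-(diethylamino)propyl chain gives a 3.4-fold higher number from compound 3 to compound 4 (0.53 log units; beyond the scatter) and a 2.7-fold higher number from compound 2 to compound 4 (0.43 log units; beyond the scatter) and so moves the number beyond the scatter, which neither aromatic group did. Set against the hydroxy on the carbonyl carbon, the (3-(diethylamino)propyl)amino group gives a 4.0-fold higher number from compound 1 to compound 4 (0.60 log units; beyond the scatter) and this makes compound 4 the weakest inhibitor of the four. The earlier picture, in which three different groups at this place could not be told apart, therefore holds only for those three and does not extend to a ring-free chain ending in an amine.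

The compounds shown leave open whether the amine at the chain end or the loss of the aromatic ring goes with the rise, a question that a plain pentyl chain on the same nitrogen could address. No measurement here explains the rise itself.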